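The compounds below may be only part of what the source reports. "The series", "measured", "known", "first", "only" and "open" are said of these compounds alone.

Three compounds share one core and differ only in the aryl group that sits on the sulfonamide nitrogen. In an assay on isolated protein for binding affinity to 5-hydroxytryptamine receptor 6 (Homo sapiens) (on this read-out higher numbers stand for weaker inhibition and lower numbers for stronger inhibition), compound 1 `COc1ccc(Cl)cc1NS(=O)(=O)c1ccc(OC)c(N2CCNCC2)c1` gives 1.26 nM. Compound 2 `COc1ccc(S(=O)(=O)Nc2ccc(Cl)c(Cl)c2)cc1N1CCNCC1` gives 2.51 nM in this assay, and compound 3 `COc1ccc(S(=O)(=O)Nc2cc(Cl)c(Cl)cc2Cl)cc1N1CCNCC1` gives 5.01 nM. Compound 3 thus carries the highest number of the three: the step of a 2.0-fold higher number from compound 2 to compound 3 (0.30 log units; within the scatter) stays within the scatter, while the step of a 4.0-fold higher number from compound 1 to compound 3 (0.60 log units; beyond the scatter) goes beyond it. The step of a 2.0-fold higher number from compound 1 to compound 2 (0.30 log units; within the scatter) also stays within the scatter.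

Compound 4 `COc1ccc(S(=O)(=O)Nc2cc(Br)cc(Br)c2Br)cc1N1CCNCC1` has not been measured. It differs from compound 3 in one place: 2,3,5-tribromophenyl in place of 2,4,5-trichlorophenyl on a sulfonamide nitrogen. For the measured compounds named here, two measured steps bear on this change: a 2.0-fold higher number from compound 2 to compound 3 (0.30 log units; within the scatter), where a chloro entered in place of hydrogen, and a 4.0-fold higher number from compound 1 to compound 3 (0.60 log units; beyond the scatter), where the whole aryl group was exchanged. Both went toward higher numbers, the first within the scatter and the second modestly beyond it. The present change keeps three halogens on the ring and trades one halogen for another; the expected step is therefore small, toward a slightly higher number or none beyond the scatter. The estimated step of a 1.3-fold higher number from compound 3 to compound 4 (0.10 log units; within the scatter) rests on the step of a 2.0-fold higher number from compound 2 to compound 3 (0.30 log units; within the scatter). Compound 4 is expected to give 6.3 nM in this assay, with a range from 2.5 nM to 20 nM.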

Compound 4, inhibition constant: 2.51 nM
Compound 4: the middle estimate sits 2.5-fold (0.40 log units) above what was measured, within the range that was stated.
By their numbers in this assay, from the lowest: compounds 1, 2, 4 and 3 (each within the scatter of the next, the first and the last beyond it).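

In this assay the new compound fits among the earlier ones, with a 2.0-fold lower number from compound 3 to compound 4 (0.30 log units; within the scatter) and a 2.0-fold higher number from compound 1 to compound 4 (0.30 log units; within the scatter) and no change at the digits printed from compound 2 to compound 4 (within the scatter) as its three steps, all of them within the scatter. The earlier compounds shown here carried only chlorine on this aryl group, with or without a methoxy group, so compound 4 adds the finding that an aryl group bearing bromine instead gives a number that cannot be told apart from those of compound 1, compound 2 and compound 3, even though the one gap beyond the scatter among the earlier compounds remains a 4.0-fold higher number from compound 1 to compound 3 (0.60 log units; beyond the scatter) as the widest seen here. Nothing available explains why this exchange on a sulfonamide nitrogen leaves the number within the scatter.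

This exchange alters the halogen and its arrangement on the ring together, so the two cannot be separated, and a 2,4,5-tribromophenyl group would be needed to compare bromine with chlorine in the same arrangement. The compounds shown also leave open what happens when the aryl group carries an amine or a carboxylic acid rather than halogens or a methoxy group.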